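A few compounds are considered here, and "the series" means these few. Any claim that something is new, unique, unknown or untested is made for them only; others in the source may bear on it.

In an ADME assay on BJ cells (Homo sapiens) for cytotoxicity, read by CellTiter-Glo and resazurin assay, with a stated time of 72 h (on this read-out lower numbers stand for an effect already at smaller amounts and higher numbers for an effect only at larger amounts of compound), two compounds have been measured so far:

Compound 1, `CC(C)N(Cc1cccc(OCCCCCC(=O)O)c1)C(=O)c1ccc(-c2cccc3ccccc23)cc1`, gives < 1.3 nM.
Compound 2, `CCOC(=O)CCCCCOc1cccc(CN(C(=O)c2ccc(-c3ccc4ccccc4c3)cc2)C(C)C)c1`, gives > 26000 nM.

Neither reading is a true number. For compound 1 the value is the lower limit of this assay, (the limit of < 1.3 nM in this assay, at which 1 of the 2 values shown sits). For compound 2 the value is the upper limit of this assay, (the limit of > 26000 nM in this assay, at which 1 of the 2 values shown sits). For the measured compounds named here, compound 2 therefore stands at the far end of the two values shown: nothing more than this limit is known for it, and the only other value shown is itself a limit, so no measured step can be drawn between the two.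

Compound 3, `CCOC(=O)CCCCCOc1cccc(CN(C(=O)c2ccc(-c3cccc(OC)c3)cc2)C(C)C)c1`, differs from compound 2 in one place: 3-methoxyphenyl in place of naphthalen-2-yl on an aromatic carbon. Going by the values given here, no measured step of this kind exists among the compounds above, so the expectation rests only on where compound 2 sits. In this assay a step of no more than the usual scatter is expected, in no particular direction, leaving compound 3 at or near the same upper limit. Compound 3 is expected to give about 30000 nM, within the range 10000 nM to 100000 nM. The step that the limit leaves unreadable from compound 2 to compound 3 is estimated to be negligible.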

Compound 3, half-maximal effective concentration: > 21000 nM
Compound 3 ended at the assay's limit (the forecaster's own chance of this, stated with the estimate: 70%); the middle value is on the limit's open side.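

In this assay compound 3 gives > 21000 nM and that is a limit, not a number. Compound 2 gives > 26000 nM and that is also a limit, so no step can be read between compound 2 and compound 3. Left open is whether 3-methoxyphenyl in place of naphthalen-2-yl changes this read-out at all, and by how much.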